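The source may hold more compounds than are shown below. What is called first, only, known or untested is meant among the compounds shown, and "the series" means these compounds.

Among the compounds with values here, the three compounds measured so far share one core and differ at the group that sits on an amine nitrogen in a ring. Compound 1 `COc1ccc2c(c1)CCCC2NC(=O)CCCN1CCN(c2ccccc2OC)CC1` and compound 2 `COc1ccccc1N1CCN(CCCC(=O)NC2CCCc3cccc(OC)c32)CC1` both carry a methoxyphenyl there; in an assay on HEK293 cells for displacement of a labelled ligand from 5-hydroxytryptamine receptor 7 (Rattus norvegicus) (a lower number here means a stronger inhibitor, a higher number a weaker inhibitor), compound 1 gives 186 nM and compound 2 gives 154 nM. Compound 3 `O=C(CCCCCN1CCN(c2noc3ccccc23)CC1)NC1CCCc2ccccc21` gives 125 nM in this assay. That is the lowest of the three numbers, yet its gaps to compound 2 and to compound 1 both lie within the scatter, so the three compounds cannot be told apart by these values.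

Compound 4 `CC(=O)c1ccc(N2CCN(CCCCCC(=O)NC3CCCc4ccccc43)CC2)cc1` has not yet been measured. It differs from compound 3 in one place: a group of 9 heavy atoms (8 carbon, 1 oxygen; one six-membered aromatic ring of carbon only) in place of a group of 9 heavy atoms (7 carbon, 1 nitrogen, 1 oxygen; one five-membered aromatic ring with 2 hetero atoms, one six-membered aromatic ring of carbon only), on an amine nitrogen in a ring. Within the data shown here, no measured pair shows this exchange, so nothing in the data fixes its size. An estimate can only rest on compound 3, whose 125 nM is the closest anchor, and on the general observation that the other two groups on the ring nitrogen gave numbers within the scatter of it. Compound 4 is therefore expected to end up somewhat weaker, with a step of a 2.4-fold higher number from compound 3 to compound 4 (0.38 log units; beyond the scatter) that may or may not clear the scatter. The estimate for compound 4 in this assay is 300 nM, with a range from 100 nM to 900 nM.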

Compound 4, inhibition constant: 2640 nM
Compound 4: middle estimate off by 8.8-fold (0.94 log units), on the low side, outside the stated range (above it).
By their numbers in this assay, from the lowest: compounds 3, 2 and 1 (each within the scatter of the next); then compound 4.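

In this assay, within the data shown here, placing 4-acetylphenyl on an amine nitrogen in a ring, in place of the group that holds a five-membered aromatic ring with 2 hetero atoms, gives a 21-fold higher number from compound 3 to compound 4 (1.32 log units; beyond the scatter), a large step and the first one here between compounds that differ in one place. It shows that the group at this position can alone shift the number well beyond the scatter, even though the leaving and entering groups both have 9 heavy atoms and each has one six-membered aromatic ring of carbon only, so these shared counts do not settle the outcome. The data offer no measurement that accounts for this step.

Among these compounds, the single exchange changes several things at once, so it remains open whether the step goes with the acetyl group or with the absence of the five-membered aromatic ring; a plain phenyl on the same ring nitrogen, with the rest of compound 4 unchanged, would separate the two. Going by these compounds, it also remains open whether a step of this size would recur with a shorter chain between the ring nitrogen and the amide carbonyl.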